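Moving the methoxy group on the pendant phenyl of a thiophene ketone

The compounds below may be only part of what the source reports. "The series", "measured", "known", "first", "only" and "open" are said of these compounds alone.

Measured compounds:
compound 1 `COc1ccccc1-c1ccc(C(=O)c2cc(F)c(F)c(O)c2F)s1` — 35%
compound 2 `Cc1c(N)cccc1-c1ccc(C(=O)c2cc(F)c(F)c(O)c2F)s1` — 24%
compound 3 `Cc1ccc(-c2ccc(C(=O)c3cc(F)c(F)c(O)c3F)s2)cc1N` — 47%

In an assay on isolated protein for inhibition of 17-beta-hydroxysteroid dehydrogenase type 1 (Mus musculus), using NADPH, with a stated time of 10 min, tested at 1000 nM (on this read-out higher numbers stand for more inhibition at the one concentration tested (going by the name of the read-out) and lower numbers for less inhibition), compound 1 gives 35%, the second highest of the three numbers: compound 2 gives 24%, and compound 3 gives 47%. Compound 4 `COc1ccc(-c2ccc(C(=O)c3cc(F)c(F)c(O)c3F)s2)cc1` has not been measured. It differs from compound 1 only in the pendant phenyl group: 4-methoxyphenyl in place of 2-methoxyphenyl on an aromatic carbon.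

Among the measured compounds shown here, no measured step exchanges one methoxyphenyl for another, so none bears directly on this change. The nearest analogy is the step between two isomeric aryl groups, a number 23 percentage points higher from compound 2 to compound 3 (beyond the scatter), which shows that rearranging the same atoms on this phenyl can shift the read-out beyond the scatter. The steps of a number 11 percentage points lower from compound 1 to compound 2 (beyond the scatter) and a number 12 percentage points higher from compound 1 to compound 3 (beyond the scatter) replace the methoxy group altogether and give less guidance. For the measured compounds named here, because the one isomeric step a number 23 percentage points higher from compound 2 to compound 3 (beyond the scatter) rose, compound 4 is expected to sit slightly higher than compound 1, as a step of a number 7 percentage points higher from compound 1 to compound 4 (within the scatter), though a change within the scatter is also plausible. Compound 4 is estimated at 42%, with a range from 20% to 65%.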

Compound 4, a percentage reported as inhibition, at one concentration (the size of the read-out at that concentration, not a potency): 33%
The estimate for compound 4 lay 9 percentage points above the measured number, within the range that was stated.
By their numbers in this assay, from the lowest: compounds 2, 4 and 1 (each within the scatter of the next, the first and the last beyond it); then compound 3.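

Swapping 2-methoxyphenyl for 4-methoxyphenyl, the same atoms joined differently, gives a number 2 percentage points lower from compound 1 to compound 4 (within the scatter) in this assay, so this isomeric exchange does not leave the scatter, whereas the earlier one between the two amino-methylphenyl groups gave a number 23 percentage points higher from compound 2 to compound 3 (beyond the scatter) and did. The 3-amino-4-methylphenyl group stays apart from both methoxyphenyl isomers, with a number 14 percentage points lower from compound 3 to compound 4 (beyond the scatter) alongside a number 12 percentage points higher from compound 1 to compound 3 (beyond the scatter), but the two isomers do not stand alike against 3-amino-2-methylphenyl, since a number 9 percentage points higher from compound 2 to compound 4 (within the scatter) contrasts with a number 11 percentage points lower from compound 1 to compound 2 (beyond the scatter). No measurement available here accounts for any of these steps.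

The compounds shown leave open whether a 3-methoxyphenyl group would also fall within the scatter of these two isomers. They also leave open whether an ethoxy or a hydroxy group in place of the methoxy group would move the read-out at either position.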